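Adding a Second Chloro to a Diaryl Urea

The compounds below may be only part of what the source reports. "The series", "measured", "known", "first", "only" and "open" are said of these compounds alone.

compound 1, `Cc1cc(C)nc(Oc2ccc(NC(=O)Nc3ccccc3)cc2)n1`: "not determined" (no result reported)
compound 2, `Cc1cccc(NC(=O)Nc2ccc(Oc3nc(C)cc(C)n3)cc2)c1`: "not determined" (no result reported)
compound 3, `Cc1cc(C)nc(Oc2ccc(NC(=O)Nc3ccc(Cl)cc3)cc2)n1`: > 50000 nM

All three share a core in which a urea links two aromatic rings. In a functional assay on MGC-803 cells (Homo sapiens) for cytotoxicity, read by MTT assay, with a stated time of 3 days (a higher number here means a weaker inhibitor, a lower number a stronger inhibitor), compound 1 gives "not determined" (no result reported), and compound 2 gives "not determined" (no result reported). For compound 3 the result is only a limit, > 50000 nM. Compound 3 thus stands at the limit of > 50000 nM in this assay, at which 1 of the 3 values shown sits.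

Compound 4, `Cc1cc(C)nc(Oc2ccc(NC(=O)Nc3ccc(Cl)cc3Cl)cc2)n1`, differs from compound 3 by chloro in place of hydrogen on an aromatic carbon. For the measured compounds named here, no measured step between two compounds is available to guide an expectation, so the step from compound 3 to compound 4 is expected to lie within the scatter, a number no higher from compound 3 to compound 4 (the limit leaves the size open). Compound 4 is therefore estimated at 50000 nM, with a range from 15000 nM to 150000 nM, and quite possibly again only a limit.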

Compound 4, half-maximal inhibitory concentration: 35400 nM
Compound 4: middle estimate off by 1.4-fold (0.15 log units), on the high side; the range from low to high includes it.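

In this assay, going from 4-chlorophenyl to 2,4-dichlorophenyl gives the first result here that is a number and not a limit, and the step reads an at least 1.4-fold lower number from compound 3 to compound 4 (0.14 log units; that floor lies within the scatter). From the compounds shown here alone, a chloro at this position, ortho to a large group, therefore still leaves a measurable value, but the true size of the change stays unknown. The step is only a floor because compound 3 sits at a limit: the limit of > 50000 nM in this assay, at which 1 of the 4 values shown sits.

The compounds shown leave open how a fluoro, a methoxy or an amine at this same position would read.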